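Swapping the trifluoromethyl position on the anilino ring

The source may hold more compounds than are shown below. What is called first, only, known or untested is meant among the compounds shown, and "the series" means these compounds.

Compound 1, `FC(F)(F)c1ccc(CSc2nc(N3CCCCC3)c3ccccc3n2)cc1`, in a functional assay on HGC-27 cells (Homo sapiens) for cytotoxicity, read by MTT assay, with a stated time of 72 h; on this read-out lower numbers stand for stronger inhibition and higher numbers for weaker inhibition: > 50000 nM (a limit of the assay)
Compound 2, `FC(F)(F)c1ccc(CSc2nc(Nc3ccccc3C(F)(F)F)c3ccccc3n2)cc1`, in this assay: > 50000 nM (a limit of the assay)
Compound 3, `FC(F)(F)c1ccc(CSc2nc(Nc3cccc(C(F)(F)F)c3)c3ccccc3n2)cc1`, in this assay: 11700 nM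

Compound 3 is the only one of the three with a number rather than a limit. The step of an at least 4.2-fold lower number from compound 1 to compound 3 (0.63 log units; beyond the scatter) and the step of an at least 4.2-fold lower number from compound 2 to compound 3 (0.63 log units; beyond the scatter) both point the same way, each against a limit (the limit of > 50000 nM in this assay, at which 2 of the 3 values shown sit), so their true size is open at the top. The step that the two limits leave unreadable from compound 1 to compound 2 cannot be read, because both ends sit at a limit.

Compound 4, `FC(F)(F)c1ccc(CSc2nc(Nc3ccc(C(F)(F)F)cc3)c3ccccc3n2)cc1`, differs from compound 3 only in 4-(trifluoromethyl)phenyl in place of 3-(trifluoromethyl)phenyl on a nitrogen on an aromatic ring. Moving the trifluoromethyl from the 2- to the 3-position on the anilino ring brought the number down from a limit into the measurable range, but no measured step covers the 4-position, and one positional change alone gives no trend. Compound 4 is therefore expected to land near compound 3, with the estimated step of a 1.3-fold higher number from compound 3 to compound 4 (0.11 log units; within the scatter) inside the scatter. The estimate for compound 4 is 15000 nM, between 4000 nM and 50000 nM, with a real chance the assay reports only a limit.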

Compound 4, half-maximal inhibitory concentration: 7560 nM
Beside the measured number, compound 4's estimate is 2.0-fold (0.30 log units) above it; measured number inside the range.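

In this assay, the swap to 4-(trifluoromethyl)phenyl on the nitrogen gives a 1.5-fold lower number from compound 3 to compound 4 (0.19 log units; within the scatter), so the two groups cannot be told apart here and a measurable number is not confined to 3-(trifluoromethyl)phenyl. Against 2-(trifluoromethyl)phenyl, the same group gives an at least 6.6-fold lower number from compound 2 to compound 4 (0.82 log units; beyond the scatter), and in place of piperidin-1-yl, its amino form gives an at least 6.6-fold lower number from compound 1 to compound 4 (0.82 log units; beyond the scatter). Compound 1 and compound 2 thus remain the two that go against a measurable number, and both steps are open at the top: the limit of > 50000 nM in this assay, at which 2 of the 4 values shown sit.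

The compounds shown leave open how much of the number depends on the trifluoromethyl itself, as a nitrile, a methoxy or a chlorine on the same ring could show. They also leave open whether an unsubstituted phenylamino group would stay in the measurable range.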